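A Methyl Added to the Amide Side of Compound 3

This account rests on a few compounds, and the source may have more. Where it says the series, first, only, none or still open, it means among the compounds named here.

Three measured compounds share one core and differ only in the group on the amide nitrogen: compound 1 `O=C(NCC1CCCCC1)c1cccc(/C=C2\CC(=O)N(c3ccccc3)C2=O)c1`, compound 2 `CCOc1ccc(NC(=O)c2cccc(/C=C3\CC(=O)N(c4ccccc4)C3=O)c2)cc1` and compound 3 `COc1ccc(NC(=O)c2cccc(/C=C3\CC(=O)N(c4ccccc4)C3=O)c2)cc1`. In an ADME assay on SW480 cells (Homo sapiens) for cytotoxicity, read by MTT assay, with a stated time of 72 h (a higher number here means a weaker inhibitor, a lower number a stronger inhibitor), compound 2 gives 91500 nM. Compound 1 reaches only the limit of > 100000 nM, which is not a number. Compound 3 likewise stands at the limit > 100000 nM, so no more than a limit is known for it. Two of the three values sit at the limit of > 100000 nM in this assay, at which 2 of the 3 values shown sit. The unmeasured compound 4 `COc1ccc(NC(=O)c2cccc(/C=C3\CC(=O)N(c4ccccc4)C3=O)c2)c(C)c1` differs from compound 3 by methyl in place of hydrogen on an aromatic carbon. For the measured compounds named here, the steps that bear on this change are an at least 1.0-fold higher number from compound 2 to compound 3 (0.03 log units; that floor lies within the scatter) and an at least 1.0-fold lower number from compound 1 to compound 2 (0.03 log units; that floor lies within the scatter), both small, while a step that the two limits leave unreadable from compound 1 to compound 3. A step of a number no higher from compound 3 to compound 4 (the limit leaves the size open) is therefore expected. Compound 4 is estimated at 100000 nM, between 50000 nM and 200000 nM.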

Compound 4, half-maximal inhibitory concentration: > 100000 nM
Compound 4: only a limit was reported (the forecaster's own chance of this, stated with the estimate: 70%); the middle value lies on the limit itself.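

In this assay compound 4 gives > 100000 nM, which is a limit and not a number, so methyl at this ortho carbon brings no readable value. For the compounds shown here, the only step that can be read is an at least 1.0-fold higher number from compound 2 to compound 4 (0.03 log units; that floor lies within the scatter), and the steps that compare compound 4 with the other two compounds cannot be read. The new compound adds one more value to the cluster at the assay's limit: the limit of > 100000 nM in this assay, at which 3 of the 4 values shown sit.

On these data alone, whether methyl here changes anything below that limit stays open. So does whether another group at this carbon, such as an amine or a carboxylic acid, would give a readable number.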